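A few compounds are considered here, and "the series" means these few. Any claim that something is new, unique, unknown or untested is made for them only; others in the source may bear on it.

Compound 1 `COc1cc(C2=NN(C(C)=O)C(c3cccc(OC)c3OC)O2)cc(OC)c1OC` and compound 2 `COc1cc(C2=NN(C(C)=O)C(c3cc(OC)c(OC)c(OC)c3)O2)cc(OC)c1OC` share the same core and were both tested in a functional assay on PC-3 cells (Homo sapiens) for antiproliferative activity, read by MTT assay, tested at 5 uM; a lower number here means a weaker effect, a higher number a stronger effect of the compound at the concentration tested. Among the measured compounds shown here, compound 1 gives 58.2%, the higher of the two numbers known so far; compound 2 gives 0.1%, a result far enough below that of compound 1 to lie beyond the scatter. For the measured compounds named here, the two differ in the aryl group on the saturated ring carbon, and that is the only comparison available. Compound 3 `COc1cc(C2=NN(C(C)=O)C(c3cccc(F)c3)O2)cc(OC)c1OC` has not yet been measured in this assay. It differs from compound 1 by 3-fluorophenyl in place of 2,3-dimethoxyphenyl on a saturated ring carbon. Going by the values given here, no measured pair shows how a change of this kind shifts the read-out, and with only two numbers in hand, any expectation rests on the finding that the aryl group on the saturated ring carbon matters greatly. The step expected here is a number 23.2 percentage points lower from compound 1 to compound 3 (beyond the scatter), downward and uncertain. The estimate for compound 3 in this assay is 35%, between 5% and 70%.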

Compound 3, a percentage reported as inhibition, at one concentration (the size of the read-out at that concentration, not a potency): 43.5%
Compound 3: the middle estimate sits 8.5 percentage points below what was measured; the measured number falls inside the stated range.
By their numbers in this assay, from the lowest: compound 2; then compound 3; then compound 1.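

In this assay, the step of a number 14.7 percentage points lower from compound 1 to compound 3 (beyond the scatter) shows that the 2,3-dimethoxyphenyl group is not essential at this saturated ring carbon. The smaller 3-fluorophenyl group, which has no hydrogen-bond acceptors, costs part of the read-out but does not abolish it: compound 3 gives 43.5%, well clear of compound 2 at 0.1%. Nothing at hand explains why the number moves this way with this change.

The compounds shown leave open which part of the change produces the step, the loss of the two methoxy groups or the arrival of the fluorine. They also leave open how a plain phenyl, a 3-methoxyphenyl or a 3-chlorophenyl group would read at this same carbon.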